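The source may report more compounds than this note shows. Statements on the series, on what has been measured and on what is new or still open speak of the compounds shown alone.

Measured so far:
compound 1, `CC1=C(C(=O)Nc2ccc([N+](=O)[O-])cc2)C(c2ccc(Br)cc2)N=C(SCc2ccccc2)N1` — 13.4%
compound 2, `CC1=C(C(=O)Nc2ccc([N+](=O)[O-])cc2)C(c2cccc([N+](=O)[O-])c2)N=C(SCc2ccccc2)N1` — 10.3%

Both were tested in a functional assay on the whole organism (artery, strain albino) with Rattus norvegicus as the target, with a stated time of 120 min, at a dose of 10 mg/kg by the oral route; a higher number here means more inhibition at the dose given (going by the name of the read-out), a lower number less inhibition. Compound 2 has the lowest of the two numbers, but its nearest neighbour, compound 1, differs from it only by a number 3.1 percentage points lower from compound 1 to compound 2 (within the scatter), so the two cannot be told apart. That one step swapped the group on a saturated ring carbon of the shared core.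

Compound 3, `CC1=C(C(=O)Nc2ccc([N+](=O)[O-])cc2)C(c2cccc([N+](=O)[O-])c2)N=C(SCc2cccc(Cl)c2)N1`, has not been measured. It differs from compound 2 by chloro in place of hydrogen on an aromatic carbon, that is, benzyl becomes 3-chlorobenzyl on the sulfur side of the core. Going by the values given here, no measured pair changes this part of the molecule, so nothing among the two results bears on the step; the only known step, at a different place, stayed within the scatter.

A step of a number 1.7 percentage points higher from compound 2 to compound 3 (within the scatter) is therefore expected, with nothing beyond the scatter in either direction. Compound 3 is estimated at 12%, within a range of 2% to 25%.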

Compound 3, a percentage reported as inhibition, in the whole organism at one dose (the size of the read-out at that dose, not a potency): 12.4%
Compound 3: the middle estimate sits 0.4 percentage points below what was measured; the range from low to high includes it.
By their numbers in this assay, from the lowest: compounds 2, 3 and 1 (each within the scatter of the next).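

Going by these compounds alone, this is the first change on the sulfur side of the shared core. In this assay, going from benzylsulfanyl to (3-chlorobenzyl)sulfanyl gives a number 2.1 percentage points higher from compound 2 to compound 3 (within the scatter), so at this dose chloro and hydrogen on this aromatic carbon cannot be told apart. Neither of the two places changed so far, this one and the saturated ring carbon, has yet given a step beyond the scatter, although each rests on a single change.

On these data alone, it remains open whether a larger change on the sulfur, such as a longer chain, an amine or a carboxylic acid in place of benzyl, would move the number beyond the scatter. No measurement shown here offers an explanation for this result.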